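A few compounds are considered here, and "the series" means these few. Any claim that something is new, unique, unknown or untested is made for them only; others in the source may bear on it.

The measured compounds in this study:

Compound 1, `ClCc1ccccc1Cn1cnc2c(Cl)nc(Cl)nc21`: 8510 nM
Compound 2, `ClCc1ccccc1Cn1cnc2c(Cl)ncnc21`: > 100000 nM
Compound 3, `ClCc1ccc(Cn2cnc3c(Cl)nc(Cl)nc32)cc1`: 95500 nM

In a functional assay on SK-MEL-2 cells (Homo sapiens) for cytotoxicity, read by sulforhodamine B assay, with a stated time of 48 h (on this read-out higher numbers stand for lower toxicity in this test and lower numbers for higher toxicity in this test), compound 1 gives 8510 nM, the lowest number of the three. Compound 3 gives 95500 nM. Compound 2 stands at a limit: its value of > 100000 nM is a limit of the measurement and not a number (the limit of > 100000 nM in this assay, at which 1 of the 3 values shown sits). Among the measured compounds shown here, the one single-point step that is known is a hydrogen in place of chloro on an aromatic carbon, which gave an at least 11-fold higher number from compound 1 to compound 2 (1.07 log units; beyond the scatter).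

Compound 4, `Nc1nc(Cl)c2ncn(Cc3ccccc3CCl)c2n1`, differs from compound 2 by amino in place of hydrogen on an aromatic carbon. For the measured compounds named here, no measured step concerns an amino group at this place; the known step only shows that removing chloro from that carbon carried compound 2 to the limit. The amino substituent is therefore unsupported by any measured pair, and the expectation for compound 4 is drawn only from where compound 2 stands and from compound 1. Compound 4 is expected to give 50000 nM, within 12000 nM to 100000 nM, which would mean an estimated at least 2.0-fold lower number from compound 2 to compound 4 (0.30 log units; that floor lies within the scatter).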

Compound 4, concentration lethal to 50% of the cells: > 100000 nM
Compound 4: only a limit was reported (the forecaster's own chance of this, stated with the estimate: 40%); middle value at least 2.0-fold (0.30 log units) from the limit.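

In this assay compound 4 gives > 100000 nM, which is a limit of the assay and not a number. Amino in place of chloro on the aromatic carbon between two ring nitrogen atoms gave an at least 11-fold higher number from compound 1 to compound 4 (1.07 log units; beyond the scatter), so at this position amino, like hydrogen, does not keep the lower number of compound 1. The step from compound 2 to compound 4 cannot be read, and amino and hydrogen cannot be ranked at this position, since both compounds stand at one limit: the limit of > 100000 nM in this assay, at which 2 of the 4 values shown sit.

The compounds shown leave open whether any group other than chloro on this carbon keeps a number close to that of compound 1, as a bromo, methoxy or methylamino group might. Going by these compounds, whether amino behaves the same way with the chloromethyl group placed as in compound 3 also remains open.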